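The source may hold more compounds than are shown below. What is called first, only, known or untested is meant among the compounds shown, and "the series" means these compounds.

Series notes. Compound 1 `COc1ccc(CCCN2CCC(CNC(c3ccccc3)c3ccccc3)CC2)cc1` gives 2800 nM in a functional assay on cells (T-cell line, Homo sapiens) for inhibition (on this read-out higher numbers stand for weaker inhibition and lower numbers for stronger inhibition), and compound 2 `COc1ccc(CCCN2CCC(COCc3ccc(Cl)cc3)CC2)cc1` gives 500 nM. Compound 3 `CCCN1CCC(COC(c2ccccc2)c2ccccc2)CC1` gives 17800 nM and thus stands highest of the three numbers; compound 1 is nearer to it than compound 2, and both gaps lie beyond the scatter. Compound 4 `c1ccc(C(OCC2CCN(CC3CCc4ccccc4C3)CC2)c2ccccc2)cc1` is not yet measured. It differs from compound 3 by 1,2,3,4-tetrahydronaphthalen-2-yl in place of ethyl on a saturated chain carbon bound to an amine nitrogen in a ring. A downward step of moderate size is expected here, because compound 1 gives 2800 nM and compound 2 gives 500 nM, both well under compound 3, though neither carries the group that enters in compound 4. The estimate for compound 4 is 1500 nM, within 300 nM to 8000 nM. The expected step is a 12-fold lower number from compound 3 to compound 4 (1.07 log units; beyond the scatter).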

Compound 4, half-maximal inhibitory concentration: 5600 nM
Beside the measured number, compound 4's estimate is 3.7-fold (0.57 log units) below it, within the range that was stated.
By their numbers in this assay, from the lowest: compound 2; then compounds 1 and 4 (each within the scatter of the next); then compound 3.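

In this assay, going by these compounds alone, 1,2,3,4-tetrahydronaphthalen-2-yl in place of ethyl gives a 3.2-fold lower number from compound 3 to compound 4 (0.50 log units; beyond the scatter) as the first paired reading at this position. A saturated chain carbon bound to an amine nitrogen in a ring therefore accepts a far larger, two-ring group, and the number still falls modestly. Nothing on hand accounts for the step.

Going by these compounds, it remains open whether the step follows the added carbons or the aromatic ring. A hexyl chain or a cyclohexyl group in the same place would separate the two.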